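This account rests on a few compounds, and the source may have more. Where it says the series, first, only, none or still open, it means among the compounds named here.

Compound 1 `O=C(O)c1ccccc1-c1ccc(CCc2ncc(Cc3ccccc3F)[nH]2)cc1` gives 9.5 nM in an in vitro functional assay on cells for agonist activity at Bombesin receptor subtype-3 (Mus musculus), read by luminescence and calcium flux; a higher number here means that more compound is needed for the effect, a lower number that less compound is needed. Compound 2 `O=C(O)c1ccccc1-c1ccc(CCc2ncc(Cc3cccc(F)c3)[nH]2)cc1` gives 7.9 nM. Compound 3 `O=C(O)c1ccccc1-c1ccc(CCc2ncc(CC3CC3)[nH]2)cc1` gives 72 nM.

Compound 3 stands highest of the three, so it needs the most compound for the same effect. Compound 4 `O=C(O)c1ccccc1-c1ccc(CCc2ncc(Cc3cccc(F)c3F)[nH]2)cc1` differs from it in one place: 2,3-difluorophenyl in place of cyclopropyl on a saturated chain carbon bound to an aromatic carbon. Two measured steps run the other way along this same path: a 7.6-fold higher number from compound 1 to compound 3 (0.88 log units; beyond the scatter) and a 9.1-fold higher number from compound 2 to compound 3 (0.96 log units; beyond the scatter), both beyond the scatter. Moving a single fluorine around the ring changed little, as a 1.2-fold lower number from compound 1 to compound 2 (0.08 log units; within the scatter) shows. Putting an aromatic ring back in place of cyclopropyl is therefore expected to lower the number in this assay by a similar margin, estimated as a 9.0-fold lower number from compound 3 to compound 4 (0.95 log units; beyond the scatter). Compound 4 is expected to give about 8 nM, within a range of 3 nM to 25 nM.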

Compound 4, half-maximal effective concentration: 8 nM
Estimate against measurement, compound 4: no gap at the digits printed, within the range that was stated.
By their numbers in this assay, from the lowest: compounds 2, 4 and 1 (each within the scatter of the next); then compound 3.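

The 2,3-difluorophenyl group sits level with the two singly fluorinated rings in this assay: adding a second fluoro in place of hydrogen gives a 1.0-fold higher number from compound 2 to compound 4 (0.01 log units; within the scatter) and a 1.2-fold lower number from compound 1 to compound 4 (0.07 log units; within the scatter). The larger step, a 9.0-fold lower number from compound 3 to compound 4 (0.95 log units; beyond the scatter), now holds for a third aromatic ring, so having that ring in place of cyclopropyl matters here and the fluorine count does not go beyond the scatter. Nothing available explains why these numbers differ.

Still open, from the compounds shown here alone, is whether an unsubstituted phenyl, a chlorophenyl or a cyclohexyl at this place would match the fluorinated rings or cyclopropyl.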